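This account rests on a few compounds, and the source may have more. Where it says the series, first, only, none or still open, it means among the compounds named here.

Measured so far in a functional assay on PC-9 cells (Homo sapiens) for inhibition, read by MTT assay, with a stated time of 72 h; a higher number here means a weaker inhibitor, a lower number a stronger inhibitor
Compound 1 `Cc1cc(Nc2ccn(Cc3cccc4ccccc34)n2)n2nc(SCc3ccc(Br)cc3)nc2n1` gives 5660 nM
Compound 2 `Cc1cc(Nc2ccn(Cc3ccccc3)n2)n2nc(SCc3ccc(Br)cc3)nc2n1` gives > 50000 nM
Compound 3 `Cc1ccc(CSc2nc3nc(C)cc(Nc4cc(-c5ccccc5)[nH]n4)n3n2)cc1` gives 7310 nM

Compound 2 stands at the limit of > 50000 nM in this assay, at which 1 of the 3 values shown sits, and this is a limit, not a number. Compound 4 `Cc1cc(Nc2ccn(Cc3csc4ccc(Cl)cc34)n2)n2nc(SCc3ccc(Br)cc3)nc2n1` alters one group of compound 2, with 5-chloro-1-benzothiophen-3-yl in place of phenyl on a saturated chain carbon bound to an aromatic nitrogen, and the counted difference is 5-chloro-1-benzothiophen-3-yl in place of phenyl on a saturated chain carbon bound to an aromatic nitrogen in full. Within the data shown here, the one measured step that bears on this is an at least 8.8-fold higher number from compound 1 to compound 2 (0.94 log units; beyond the scatter) where phenyl took the place of naphthalen-1-yl on that same carbon. Compound 4 likewise holds two aromatic rings there. A step of similar size in the opposite direction is therefore expected, an estimated at least 10-fold lower number from compound 2 to compound 4 (1.00 log units; beyond the scatter) toward a stronger inhibitor. For compound 4 the expected value is 5000 nM with an estimated range of 1300 nM to 22000 nM as its spread.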

Compound 4, half-maximal inhibitory concentration: 4350 nM
Compound 4: the middle estimate sits 1.1-fold (0.06 log units) above what was measured; the range from low to high includes it.
By their numbers in this assay, from the lowest: compounds 4, 1 and 3 (each within the scatter of the next). At a limit, above all of these: compound 2.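

The step to 5-chloro-1-benzothiophen-3-yl on this carbon gives an at least 11-fold lower number from compound 2 to compound 4 (1.06 log units; beyond the scatter), so a second group holding two aromatic rings stands apart from the single phenyl ring. Compound 2 carries only a limit: the limit of > 50000 nM in this assay, at which 1 of the 4 values shown sits.

The two groups with two aromatic rings cannot be told apart, with a 1.3-fold lower number from compound 1 to compound 4 (0.11 log units; within the scatter), so the sulfur and chlorine bring no readable change over naphthalen-1-yl.

From the compounds shown here alone, whether the chlorine matters on its own remains open. So does what an amine or a carboxylic acid on the same ring system would do at this position.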